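A Naphthyl Swap on a Vero Cytotoxicity Series

The source may report more compounds than this note shows. Statements on the series, on what has been measured and on what is new or still open speak of the compounds shown alone.

Among the measured compounds shown here, compound 2 `CN1Cc2ccc(OCc3ccc(-c4cccc(Cl)c4)cc3)cc2[C@@H](O)C1` holds the only number in this set: in an ADME assay on Vero cells (Chlorocebus sabaeus) for cytotoxicity, read by sulforhodamine B assay, with a stated time of 72 h (on this read-out lower numbers stand for stronger inhibition and higher numbers for weaker inhibition), compound 2 gives 25500 nM. Compound 1 `COc1ccc(COc2ccc3c(c2)[C@@H](O)CN(C)C3)cc1` sits at a limit of this assay, > 50000 nM, which is the limit of > 50000 nM in this assay, at which 1 of the 2 values shown sits. For the measured compounds named here, the single measured step, an at least 1.9-fold lower number from compound 1 to compound 2 (0.29 log units; that floor lies within the scatter), is the only guide available. Compound 3 `CN1Cc2ccc(OCc3ccc(-c4ccc5ccccc5c4)cc3)cc2[C@@H](O)C1` differs from compound 2 by naphthalen-2-yl in place of 3-chlorophenyl on an aromatic carbon. Going by the values given here, since the one measured step lies within the scatter, compound 3 is expected to move only slightly, with a step of a 1.3-fold lower number from compound 2 to compound 3 (0.11 log units; within the scatter). In this assay compound 3 is estimated at 20000 nM, between 8000 nM and 50000 nM.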

Compound 3, half-maximal inhibitory concentration: 310 nM
The estimate for compound 3 lay 65-fold (1.81 log units) above the measured number; the measured number lies below the stated range.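

At this aromatic carbon, para to a large group, the read-out in this assay proves sharply sensitive to which aryl group is present: naphthalen-2-yl in place of 3-chlorophenyl gives an 82-fold lower number from compound 2 to compound 3 (1.92 log units; beyond the scatter), although the earlier step from methoxy had a floor within the scatter. Measured against methoxy, naphthalen-2-yl gives an at least 160-fold lower number from compound 1 to compound 3 (2.20 log units; beyond the scatter) and so clears the scatter. That second step rests on a limit, held by compound 1: the limit of > 50000 nM in this assay, at which 1 of the 3 values shown sits.

As far as these compounds go, whether the second fused ring or the loss of chlorine carries the drop stays open. The compounds shown also leave open how an unsubstituted phenyl, a quinolinyl or an aminophenyl at this carbon would read.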